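A few compounds are considered here, and "the series" means these few. Any claim that something is new, unique, unknown or untested is made for them only; others in the source may bear on it.

Three compounds share one core and differ only at an amine nitrogen. Compound 1 `CN(CC(=O)Nc1nc2ccc(OC(F)(F)F)cc2s1)C(=O)CN` carries that amine unsubstituted. In a physicochemical assay for pharmacokinetics, at pH 7.4 (a higher number here means that the compound lasts longer, a lower number that the compound disappears faster), compound 1 gives only a limit of the assay, < 0.1 h. Compound 2 `CNCC(=O)N(C)CC(=O)Nc1nc2ccc(OC(F)(F)F)cc2s1` has methyl in place of hydrogen on the amine nitrogen, and in this assay compound 2 likewise gives only a limit, < 0.1 h. Compound 3 `CCNCC(=O)N(C)CC(=O)Nc1nc2ccc(OC(F)(F)F)cc2s1` has ethyl in place of hydrogen on the amine nitrogen. In this assay compound 3 also gives only a limit, < 0.25 h. So compound 3 stands where every value shown stands: at a limit rather than a number, two of them at the limit of < 0.1 h in this assay, at which 2 of the 3 values shown sit, and one at the limit of < 0.25 h in this assay, at which 1 of the 3 values shown sits. The steps a step that the two limits leave unreadable from compound 1 to compound 2, a step that the two limits leave unreadable from compound 1 to compound 3 and a step that the two limits leave unreadable from compound 2 to compound 3 are all unreadable.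

Compound 4 `CC(C)NCC(=O)N(C)CC(=O)Nc1nc2ccc(OC(F)(F)F)cc2s1` differs from compound 3 by methyl in place of hydrogen on a saturated chain carbon bound to an amine nitrogen and a saturated chain carbon. Going by the values given here, the nearest measured change is the step from compound 2 to compound 3, one bond closer to the nitrogen, but a step that the two limits leave unreadable from compound 2 to compound 3 gives no size, and no other step does. The step that the limit leaves unreadable from compound 3 to compound 4 is therefore expected to be small, within the scatter. Compound 4 is estimated at 0.2 h, between 0.05 h and 0.8 h, and is expected most likely to come back as a limit again.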

Compound 4, half-life: > 24 h
Compound 4 gave a limit, no number (the forecaster's own chance of this, stated with the estimate: 60%); at least 120-fold (2.07 log units) between middle value and limit.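

In this assay, going by these compounds alone, ethyl to isopropyl on the amine nitrogen gives an at least 96-fold higher number from compound 3 to compound 4 (1.98 log units; beyond the scatter), the first step at this position that can be read, since the steps among compound 1, compound 2 and compound 3 cannot. Isopropyl in place of methyl gives an at least 240-fold higher number from compound 2 to compound 4 (2.38 log units; beyond the scatter), and isopropyl in place of hydrogen gives an at least 240-fold higher number from compound 1 to compound 4 (2.38 log units; beyond the scatter), so a single added methyl on the saturated chain carbon bound to the amine nitrogen separates compound 4 from the other compounds shown. Compound 4 gives a limit and not a number, and it is alone at that limit: the limit of > 24 h in this assay, at which 1 of the 4 values shown sits.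

How far compound 4 lies past its limit stays open, and the compounds shown give no cause for the step. From the compounds shown here alone, whether cyclopropyl or tert-butyl on the same amine nitrogen would give a step of this kind also stays open.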